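From 4-chlorophenyl to 2-methoxyphenyl on the shared core

A few compounds are considered here, and "the series" means these few. Any claim that something is new, unique, unknown or untested is made for them only; others in the source may bear on it.

In a physicochemical assay for lipophilicity, read by HPLC, at pH 7.5 (a lower number here means a more polar compound, a higher number a more lipophilic compound), compound 3 `CC[C@@H](Nc1c(C#N)c(-c2ccc(-c3ccc(Cl)cc3)cc2)nc2cnccc12)C(N)=O` gives 3.1, level with compound 2 `CC[C@@H](Nc1c(C#N)c(-c2ccc(-c3cccc(Cl)c3OC)cc2)nc2cnccc12)C(N)=O` at 3.1, while compound 1 `CC[C@@H](Nc1c(C#N)c(-c2ccc(-c3ccccc3F)cc2)nc2cnccc12)C(N)=O` gives 2.7. Compound 4 `CC[C@@H](Nc1c(C#N)c(-c2ccc(-c3ccccc3OC)cc2)nc2cnccc12)C(N)=O` keeps the shared core but has 2-methoxyphenyl in place of 4-chlorophenyl on an aromatic carbon. Among the compounds with values here, three measured steps bear on this. The data show a number 0.40 log units higher from compound 1 to compound 3 (beyond the scatter) and a number 0.40 log units higher from compound 1 to compound 2 (beyond the scatter), both modest, but no change at the digits printed from compound 2 to compound 3 (within the scatter). Within the data shown here, compound 4 carries no chlorine, and neither does compound 1, the one compound of the three at 2.7. A modest downward step is therefore expected, a number 0.40 log units lower from compound 3 to compound 4 (beyond the scatter). The estimated value for compound 4 is 2.7, within an expected range of 2.4 to 3.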

Compound 4, distribution coefficient: 2.7
Compound 4: the middle estimate sits on the measured number at the digits printed, within the range that was stated.
By their numbers in this assay, from the lowest: compounds 1 and 4 (each within the scatter of the next); then compounds 2 and 3 (each within the scatter of the next).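

In this assay hydrogen in place of chloro gives a number 0.40 log units lower from compound 2 to compound 4 (beyond the scatter) as a single change on the ring, and 2-methoxyphenyl in place of 4-chlorophenyl gives a number 0.40 log units lower from compound 3 to compound 4 (beyond the scatter) of the same size. Methoxy in place of fluoro gives no change at the digits printed from compound 1 to compound 4 (within the scatter) and so does not separate these two groups. Among these four compounds, the two carrying chlorine therefore stand apart from the two without it, with no exception. Nothing measured here explains this split. From the compounds shown here alone, whether a bromo, an amine or a carboxylic acid on this ring would fall with either pair stays open.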